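Aryl ether variation on the shared core, microsomal stability

This account rests on a few compounds, and the source may have more. Where it says the series, first, only, none or still open, it means among the compounds named here.

Two compounds of the series have numbers in an ADME assay on microsomes from liver (Rattus norvegicus) for metabolic stability, with a stated time of 40 min, tested at 10 uM (a lower number here means that less of the compound is left, a higher number that more of the compound is left), so far. Compound 2 `CCS(=O)(=O)Nc1ccc(Oc2cc(F)c(F)c(F)c2)c(-c2cn(C)c(=O)c3cncn23)c1` gives 54.3% and stands highest of the two, while compound 1 `Cn1cc(-c2cc(NS(C)(=O)=O)ccc2Oc2cccc(Br)c2)n2cncc2c1=O` gives 34.9%, a value lower by a gap beyond the scatter. Compound 3 `CCS(=O)(=O)Nc1ccc(Oc2cc(F)ccc2C)c(-c2cn(C)c(=O)c3cncn23)c1` has not yet been measured. It differs from compound 2 in a single place: 5-fluoro-2-methylphenyl in place of 3,4,5-trifluorophenyl on an oxygen on an aromatic ring. Among the compounds with values here, no pair of measured compounds separated by one change is available, so the only anchor for compound 3 is where compound 2 stands in this assay. A modest downward step is expected, of a size that could still fall within the scatter; the expected step is a number 9.3 percentage points lower from compound 2 to compound 3 (within the scatter). For compound 3 the estimate in this assay is 45%, with an expected range from 25% to 65%.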

Compound 3, percent of the compound remaining: 7.6%
Beside the measured number, compound 3's estimate is 37.4 percentage points above it; measured number outside the range, below it.
By their numbers in this assay, from the lowest: compound 3; then compound 1; then compound 2.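

In this assay, the aryl group on the ether oxygen proves highly sensitive to change: 5-fluoro-2-methylphenyl in place of 3,4,5-trifluorophenyl gives a number 46.7 percentage points lower from compound 2 to compound 3 (beyond the scatter), with the rest of the molecule unchanged. Compound 1 and compound 2 differ in more than one place and could not isolate this position, whereas this pair shows that a change in this aryl group alone is enough for a large step. Nothing measured here accounts for the size of that step.

The change alters the ring's methyl and fluorine substitution together, leaving open which part of it carries the step. Also open, on these data alone, is whether a 3-fluorophenyl, a 2-methylphenyl or a 2-methoxyphenyl group on the same oxygen would stand nearer compound 2 or compound 3.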